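This account rests on a few compounds, and the source may have more. Where it says the series, first, only, none or still open, it means among the compounds named here.

Measured compounds in a functional assay on cells for positive allosteric modulation of metabotropic glutamate receptor 5 (Rattus norvegicus), read by calcium flux; a lower number here means that less compound is needed, a higher number that more compound is needed for the effect:
compound 1, `Cc1ccc(C(=O)Nc2cc(-c3ccccc3)nn2-c2ccccc2)cc1`, giving 64 nM
compound 2, `COc1cccc(-n2nc(-c3ccccc3)cc2NC(=O)c2ccccc2)c1`, giving 570 nM
compound 3, `O=C(Nc1cc(-c2ccccc2)nn1-c1ccccc1Br)c1ccc([N+](=O)[O-])cc1`, giving 61 nM

Compound 1 stands second highest of the three numbers. Its nearest neighbour is compound 3, whose value lies within the scatter of that of compound 1, so no order between those two can be read. Compound 2 is the furthest away, with a number well beyond the scatter above that of compound 1.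

Compound 4, `O=C(Nc1cc(-c2ccccc2)nn1-c1ccccc1)C1CCCC1`, has not been measured in this assay. It differs from compound 1 in one place: cyclopentyl in place of 4-methylphenyl on a carbonyl carbon. Among the compounds with values here, no step between two measured compounds of this kind is available, so the size of the step can only be guessed. The expectation is a step of a 5.5-fold higher number from compound 1 to compound 4 (0.74 log units; beyond the scatter), towards a higher number, beyond the scatter, since compound 4 loses the aromatic ring that is present on the carbonyl carbon in all three measured compounds. For compound 4 the estimated value in this assay is 350 nM, with a range from 100 nM to 2000 nM.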

Compound 4, half-maximal effective concentration: 3410 nM
Compound 4: the middle estimate sits 9.7-fold (0.99 log units) below what was measured, and the stated range ends below it.
By their numbers in this assay, from the lowest: compounds 3 and 1 (each within the scatter of the next); then compound 2; then compound 4.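

In this assay, within the data shown here, the group on the carbonyl carbon proves decisive: cyclopentyl in place of 4-methylphenyl gives a 53-fold higher number from compound 1 to compound 4 (1.73 log units; beyond the scatter), a large step and the first change confined to one place. On the core of compound 1, a five-membered non-aromatic ring of carbon therefore does not stand in for a six-membered aromatic ring of carbon, although neither group carries a hydrogen-bond donor, a hydrogen-bond acceptor or a net charge. Nothing available explains the size of this step, and ring size, aromaticity and the loss of the methyl group remain unseparated.

Cyclohexyl would separate ring size from aromaticity, while a pyridyl ring would test whether an aromatic ring containing nitrogen holds the value of compound 1. From the compounds shown here alone, whether the step carries over to cores with a substituted ring on nitrogen also remains open.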